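Cyclohexylcarbamoylmethyl replacement on the aromatic nitrogen

This account rests on a few compounds, and the source may have more. Where it says the series, first, only, none or still open, it means among the compounds named here.

Three compounds of this series have numbers in a functional assay on HL-60 cells (Homo sapiens) for cytotoxicity, read by MTT assay, with a stated time of 24 h; on this read-out lower numbers stand for stronger inhibition and higher numbers for weaker inhibition. Compound 1 `Nc1nn(Cc2cn(-c3ccc(F)c(Cl)c3)nn2)c2nc(-c3ccccc3)cc(C(F)(F)F)c12` gives 35 ug/mL. Compound 2 `Nc1nn(Cc2cn(CC(=O)Nc3c(F)cccc3F)nn2)c2nc(-c3ccccc3)cc(C(F)(F)F)c12` gives 32.8 ug/mL, and compound 3 `Nc1nn(Cc2cn(CC(=O)Nc3ccccc3Br)nn2)c2nc(-c3ccccc3)cc(C(F)(F)F)c12` gives 27.2 ug/mL. Compound 1 has the largest of the three numbers, but its steps to the others are a 1.1-fold lower number from compound 1 to compound 2 (0.03 log units; within the scatter) and a 1.3-fold lower number from compound 1 to compound 3 (0.11 log units; within the scatter), both within the scatter, and the step between the two amide compounds, a 1.2-fold lower number from compound 2 to compound 3 (0.08 log units; within the scatter), is also within the scatter; no ranking follows from these numbers.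

Compound 4 `Nc1nn(Cc2cn(CC(=O)NC3CCCCC3)nn2)c2nc(-c3ccccc3)cc(C(F)(F)F)c12` is not yet measured. The change from compound 1 is (cyclohexylcarbamoyl)methyl in place of 3-chloro-4-fluorophenyl on an aromatic nitrogen. The relevant steps are the two that already replace the 3-chloro-4-fluorophenyl with a carbamoylmethyl group bearing an aryl amide, both within the scatter. Among the compounds with values here, compound 4 carries a cyclohexyl amide instead, a non-aromatic ring; no measured pair covers that exchange, so the expectation rests on the flatness seen so far. Compound 4 is therefore expected to give 31 ug/mL, with a range from 15 ug/mL to 62 ug/mL, and the expected step of a 1.1-fold lower number from compound 1 to compound 4 (0.05 log units; within the scatter) is not anticipated to exceed the scatter.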

Compound 4, half-maximal inhibitory concentration: 43 ug/mL
Compound 4: middle estimate off by 1.4-fold (0.14 log units), on the low side; low and high end bracket the measured number.
By their numbers in this assay, from the lowest: compounds 3, 2, 1 and 4 (each within the scatter of the next).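

In this assay, a non-aromatic ring on the amide-type nitrogen gives a number within the scatter of both aryl amides (a 1.3-fold higher number from compound 2 to compound 4 (0.12 log units; within the scatter); a 1.6-fold higher number from compound 3 to compound 4 (0.20 log units; within the scatter)). The (cyclohexylcarbamoyl)methyl group also stays within the scatter of the 3-chloro-4-fluorophenyl group on the aromatic nitrogen (a 1.2-fold higher number from compound 1 to compound 4 (0.09 log units; within the scatter)), so across these four compounds neither an aromatic ring nor a halogen in this group is needed for a number of this size. No available evidence bears on this result.

From the compounds shown here alone, whether an amine, a carboxylic acid or a longer chain in place of the cyclohexyl would give a step beyond the scatter remains open. Also open, going by these compounds, is whether changes elsewhere on the shared core would move the number more than changes at this position.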